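The source may report more compounds than this note shows. Statements on the series, on what has been measured and on what is new or still open speak of the compounds shown alone.

Measured compounds:
compound 1 `Cc1nn(C)c2c1C(c1ccccc1Cl)=NCC(=O)N2` — a functional assay on the whole organism (strain Holtzman) with Rattus norvegicus as the target; on this read-out lower numbers stand for an effect already at smaller amounts and higher numbers for an effect only at larger amounts of compound: 2.5 mg/kg
compound 2 `CCCc1nn(C)c2c1C(c1ccccc1Cl)=NCC(=O)N2` — this assay: > 40 mg/kg, a limit of the assay and not a number

Compound 1 holds the only number shown in this assay; the other value is a limit. For compound 2 the assay reports only a limit (the limit of > 40 mg/kg in this assay, at which 1 of the 2 values shown sits). The measured step reads an at least 16-fold higher number from compound 1 to compound 2 (1.20 log units; beyond the scatter).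

Compound 3 `CCn1nc(C)c2c1NC(=O)CN=C2c1ccccc1Cl` is not yet measured in this assay. It differs from compound 1 by methyl in place of hydrogen on a saturated chain carbon bound to an aromatic nitrogen. Going by the values given here, the one measured step sits on a saturated chain carbon bound to an aromatic carbon, not on the carbon bound to the aromatic nitrogen, so it bears on compound 3 only as a sign that a longer chain on the shared core can cost a great deal. A smaller loss, possibly none beyond the scatter, is expected for compound 3, with a 2.0-fold higher number from compound 1 to compound 3 (0.30 log units; within the scatter) as the estimated step. Compound 3 is estimated at 5 mg/kg, ranging from 1.5 mg/kg to 20 mg/kg.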

Compound 3, minimum effective dose: 5 mg/kg
Estimate against measurement, compound 3: no gap at the digits printed; low and high end bracket the measured number.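

In this assay, the methyl to ethyl change on a saturated chain carbon bound to an aromatic nitrogen gives a 2.0-fold higher number from compound 1 to compound 3 (0.30 log units; within the scatter), so at this position the longer chain shows no shift that can be told from repeated measurement. The earlier pair covered only the saturated chain carbon bound to an aromatic carbon, where the change gave an at least 16-fold higher number from compound 1 to compound 2 (1.20 log units; beyond the scatter); on the shared core, then, a longer chain does not carry the same cost at both places. Compound 2 stands as a limit and not a number: the limit of > 40 mg/kg in this assay, at which 1 of the 3 values shown sits.

From the compounds shown here alone, whether the carbon bound to the aromatic nitrogen also accepts a propyl or benzyl group, or a chain ending in an amine or a carboxylic acid, stays open. With one step at each place, the gap between the two places has no size.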